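A few compounds are considered here, and "the series" means these few. Any claim that something is new, unique, unknown or untested is made for them only; others in the source may bear on it.

Measured so far in an ADME assay on liver (Mus musculus) for metabolic stability, read by LC-MS, using microsomes and NADPH; a lower number here means that less of the compound is left, a higher number that more of the compound is left:
- compound 1 `CCCN(Cc1ccc(OCCn2c(=O)ccn(C)c2=O)c(C)c1)C(CC(=O)O)c1ccc(Cl)cc1`: 23%
- compound 2 `Cc1cc(CN(C2CCC2)C(CC(=O)O)c2ccc(Cl)cc2)ccc1OCCn1c(=O)ccn(C)c1=O`: 22%
- compound 3 `CCCN(Cc1ccc(OCCn2c(=O)ccn(C)c2=O)c(OC)c1)C(CC(=O)O)c1ccc(Cl)cc1`: 50%

Compound 3 has the highest number of the three, at 50%, and lies beyond the scatter from both others. Next in the series is compound 4 `CCCCN(Cc1ccc(OCCn2c(=O)ccn(C)c2=O)c(OC)c1)C(CC(=O)O)c1ccc(Cl)cc1`, which carries butyl where compound 3 carries propyl on the amine nitrogen: methyl in place of hydrogen on a saturated chain carbon, three bonds along the chain from an amine nitrogen, the propyl to butyl difference.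

Among the compounds with values here, two measured steps bear on this. The closer one, a change of the group on the amine nitrogen, is a number 1 percentage points lower from compound 1 to compound 2 (within the scatter), with cyclobutyl in place of propyl. The other, a number 27 percentage points higher from compound 1 to compound 3 (beyond the scatter), is methoxy in place of methyl on an aromatic carbon and is a change elsewhere in the molecule. From the compounds shown here alone, no change on the amine nitrogen has been measured with the methoxy in place, so that transfer is untested. Only a small shift is therefore expected, with none beyond the scatter. The expected step is a number 5 percentage points lower from compound 3 to compound 4 (within the scatter). The estimate for compound 4 is 45%, with an expected range of 30% to 60%.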

Compound 4, percent of the compound remaining: 37%
Beside the measured number, compound 4's estimate is 8 percentage points above it; low and high end bracket the measured number.
By their numbers in this assay, from the lowest: compounds 2 and 1 (each within the scatter of the next); then compound 4; then compound 3.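

With the methoxy in place, the propyl to butyl difference on the amine nitrogen is a real change in this assay: a number 13 percentage points lower from compound 3 to compound 4 (beyond the scatter). Within the data shown here, the only earlier step on this nitrogen, a number 1 percentage points lower from compound 1 to compound 2 (within the scatter), had methyl on the aromatic carbon and cyclobutyl as the new group, so it differs from the new step in both respects, and the two cannot be read as one trend. Nothing at hand accounts for the drop on adding this methyl to the chain.

Open, from the compounds shown here alone, is whether the number keeps moving along the chain, with ethyl or pentyl on the amine nitrogen, and whether cyclobutyl behaves with the methoxy as it does with the methyl. The compounds shown also leave open where on compound 4 the loss takes place.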